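A few compounds are considered here, and "the series" means these few. Any claim that something is new, unique, unknown or untested is made for them only; others in the source may bear on it.

Of the compounds shown here, three built on a shared core have been tested in an ADME assay on Huh-7 cells (Homo sapiens) for cytotoxicity, read by MTT assay, with a stated time of 96 h; a lower number here means that less compound is tolerated, a higher number that more compound is tolerated. Compound 1 `COc1cc(NCc2ccc(Cl)s2)ccc1-c1cnco1` gives 43200 nM in this assay, and compound 3 `COc1cc(NCc2cc(OC)c(OC)c(OC)c2)ccc1-c1cnco1` gives 36600 nM; the two numbers lie within the scatter of each other, so neither can be ranked above the other, and compound 1 simply stands among the numbers recorded rather than apart from them. Compound 2 `COc1cc(/N=C/C=C/c2ccccc2)ccc1-c1cnco1` yields only a limit in this assay and not a number, > 100000 nM. The result for compound 2 is the limit of > 100000 nM in this assay, at which 1 of the 3 values shown sits.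

Compound 4 `COc1cc(NCc2ccncc2)ccc1-c1cnco1` has not yet been measured in this assay. Relative to compound 1 it carries pyridin-4-yl in place of 5-chlorothiophen-2-yl on a saturated chain carbon bound to a nitrogen on an aromatic ring. Both groups that swap are aromatic rings of the same heavy-atom count, each with one hetero atom and one hydrogen-bond acceptor, and the shared core is unchanged. Going by the values given here, no measured pair shows a step, so the expectation rests on the spread of the numbers at hand. The step from compound 1 to compound 4, a 1.1-fold lower number from compound 1 to compound 4 (0.03 log units; within the scatter), is expected to stay within the scatter rather than move in either direction. Compound 4 is therefore estimated at 40000 nM, with a range from 15000 nM to 100000 nM.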

Compound 4, half-maximal cytotoxic concentration: 72200 nM
For compound 4 the middle estimate is 1.8-fold (0.26 log units) below the measured one, within the range that was stated.
By their numbers in this assay, from the lowest: compounds 3, 1 and 4 (each within the scatter of the next). At a limit, above all of these: compound 2.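

Going by these compounds alone, the swap of 5-chlorothiophen-2-yl for pyridin-4-yl, on a saturated chain carbon bound to a nitrogen on an aromatic ring, gives the first step that can be read at this position in this assay: a 1.7-fold higher number from compound 1 to compound 4 (0.22 log units; within the scatter). At this place, then, a five-membered aromatic ring bearing chlorine and a six-membered aromatic ring with the same heavy-atom count cannot be ranked against each other, even though the two rings differ in size and in their hetero atom. No measurement shown bears on this step.

Within the data shown here, the single pair leaves open whether the same holds for pyridin-3-yl or pyridin-2-yl, or for an unsubstituted thiophen-2-yl. Also open, as far as these compounds go, is what a saturated amine such as piperidin-4-yl, a carboxylic acid on the ring, or a longer chain in place of the methyl of (pyridin-4-yl)methyl would give.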